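The source may report more compounds than this note shows. Statements on the series, on what has been measured and on what is new or still open speak of the compounds shown alone.

Compound 1 `CCCCCCCCO[C@@H]1O[C@@H](C)[C@H](OC(=O)CCCCC)[C@@H](O[C@@H]2O[C@@H](C)[C@H](OC(C)=O)[C@@H](O[C@@H]3O[C@@H](C)[C@H](OC(C)=O)[C@@H](OC(C)=O)[C@H]3O)[C@H]2OC(C)=O)[C@H]1O`: 10000 nM
Compound 2 `CCCCCCCCO[C@@H]1O[C@@H](C)[C@H](OC(=O)CCCCC)[C@@H](O[C@@H]2O[C@@H](C)[C@H](OC(C)=O)[C@@H](O)[C@H]2OC(C)=O)[C@H]1O`: > 500000 nM

In a functional assay on NCI-H460 cells (Homo sapiens) for antiproliferative activity, read by MTT assay, with a stated time of 48 h (on this read-out higher numbers stand for weaker inhibition and lower numbers for stronger inhibition), compound 1 gives 10000 nM. In the same assay compound 2 gives only > 500000 nM, which is a limit of the assay and not a number. Compound 2 therefore stands at the limit of > 500000 nM in this assay, at which 1 of the 2 values shown sits, the weak end of what is shown. Compound 3 `CCCCCCCCO[C@@H]1O[C@@H](C)[C@H](OC(=O)CCCCC)[C@@H](O[C@@H]2O[C@@H](C)[C@H](OC(C)=O)[C@@H](OC(=O)CCC)[C@H]2OC(C)=O)[C@H]1O` differs from compound 2 by propylcarbonyl in place of hydrogen on an oxygen on a saturated carbon. Among the measured compounds shown here, no measured pair shows this change, so the size is uncertain; the expectation is a move toward stronger inhibition, beyond the usual scatter, with an estimated step of an at least 8.3-fold lower number from compound 2 to compound 3 (0.92 log units; beyond the scatter). Compound 3 is expected near 60000 nM, within 8000 nM to 500000 nM.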

Compound 3, half-maximal inhibitory concentration: 32000 nM
Compound 3: middle estimate off by 1.9-fold (0.27 log units), on the high side; measured number inside the range.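

In this assay, changing hydroxy to (propylcarbonyl)oxy on this oxygen gives an at least 15-fold lower number from compound 2 to compound 3 (1.19 log units; beyond the scatter), so what sits at this position clearly matters for the read-out. The true size of the step remains unknown, as the value for compound 2 is a limit and not a number: the limit of > 500000 nM in this assay, at which 1 of the 3 values shown sits.

The compounds shown leave open whether this particular ester is needed or whether other groups on this oxygen would serve equally well. A longer chain such as octanoyl, or a benzoyl group, could help separate those possibilities.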